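Adding a Third Methoxy Group to a Sulfonate Ester

The source may report more compounds than this note shows. Statements on the series, on what has been measured and on what is new or still open speak of the compounds shown alone.

Measured compounds in a functional assay on MCF7 cells (Homo sapiens) for antiproliferative activity, read by sulforhodamine B assay, with a stated time of 48 h; on this read-out lower numbers stand for stronger inhibition and higher numbers for weaker inhibition:
compound 1, `CCN1CCN(c2ccc(S(=O)(=O)Oc3ccc(OC)c(OC)c3)cc2)C1=O`, 39100 nM
compound 2, `CCN1CCN(c2ccc(S(=O)(=O)Oc3ccc(OC)cc3)cc2)C1=O`, > 100000 nM
compound 3, `CCCN1CCN(c2ccc(S(=O)(=O)Oc3cc(OC)cc(OC)c3)cc2)C1=O`, 270 nM

The value for compound 2 is a limit of this assay, not a number. In this assay compound 1 gives 39100 nM, and the change from compound 2 to compound 1, (methoxy in place of hydrogen on an aromatic carbon), gave an at least 2.5-fold lower number from compound 2 to compound 1 (0.40 log units; beyond the scatter). The difference between the cores of compound 2 and compound 3 is not broken down here; compound 3 gives 270 nM, the lowest number among the measured compounds.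

Compound 4, `CCCN1CCN(c2ccc(S(=O)(=O)Oc3cc(OC)c(OC)c(OC)c3)cc2)C1=O`, is not yet measured. It arises from compound 3 through (methoxy in place of hydrogen on an aromatic carbon), the same kind of change as from compound 2 to compound 1, though here the new group sits ortho to two methoxy groups and para to a large group rather than ortho to one methoxy group and meta to a large group. Because the earlier step gave an at least 2.5-fold lower number from compound 2 to compound 1 (0.40 log units; beyond the scatter), a further lowering is expected from compound 3 to compound 4, of about a 2.7-fold lower number from compound 3 to compound 4 (0.43 log units; beyond the scatter). Compound 4 is thus estimated at 100 nM in this assay, between 20 nM and 800 nM.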

Compound 4, half-maximal inhibitory concentration: 49 nM
The estimate for compound 4 lay 2.0-fold (0.31 log units) above the measured number, within the range that was stated.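

In this assay, the added methoxy group again went with a lower number, now on the second core, with a 5.5-fold lower number from compound 3 to compound 4 (0.74 log units; beyond the scatter). Set beside the earlier step, the change points the same way on both cores, but its size cannot be compared: the same change on two cores in this assay, an at least 2.5-fold lower number (0.40 log units; beyond the scatter) from compound 2 to compound 1 and a 5.5-fold lower number (0.74 log units; beyond the scatter) from compound 3 to compound 4; the limit leaves it open whether they differ Two pairs of compounds show a shared direction, not a rule that will hold on every core in this series.

The compounds shown leave open whether an ethoxy or a hydroxy group in the same place would match the methoxy group. They also leave open how a butyl chain on the core would affect the number.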